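The source may report more compounds than this note shows. Statements on the series, on what has been measured and on what is new or still open speak of the compounds shown alone.

Measured compounds in a functional assay on ECa-109 cells (Homo sapiens) for antiproliferative activity, read by MTT assay, with a stated time of 72 h; a lower number here means a stronger inhibitor, a higher number a weaker inhibitor:
compound 1 `CCCSc1nc(N/N=C/c2ccccc2F)c2nnn(Cc3ccccc3)c2n1`: > 64000 nM, a limit of the assay rather than a number
compound 2 `CCCSc1nc(N/N=C/c2cc(OC)c(OC)c(OC)c2)c2nnn(Cc3ccccc3)c2n1`: 4060 nM
compound 3 `C#CCSc1nc(N/N=C(\C)c2ccccc2O)c2nnn(Cc3ccccc3)c2n1`: 5250 nM

On the numbers shown, compound 1 stands apart: it is the one compound that gives only a limit, (the limit of > 64000 nM in this assay, at which 1 of the 3 values shown sits), while compound 2 and compound 3 give finite values that lie within the scatter of each other. Within the data shown here, no pair of measured compounds differs in a single place, so no measured step in this assay is available to calibrate the change from compound 1.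

Compound 4 `CCCSc1nc(N/N=C(\C)c2ccccc2)c2nnn(Cc3ccccc3)c2n1` is not yet measured. It differs from compound 1 by a group of 9 heavy atoms (8 carbon, 1 nitrogen; one six-membered aromatic ring of carbon only) in place of a group of 9 heavy atoms (7 carbon, 1 nitrogen, 1 fluorine; one six-membered aromatic ring of carbon only), on a nitrogen on an aromatic ring. The expected step in this assay from compound 1 to compound 4 is an at least 2.1-fold lower number from compound 1 to compound 4 (0.32 log units; beyond the scatter), read against a starting point that is itself only a limit, so the size of that step is uncertain in one direction. Compound 4 is expected at 30000 nM, with a range from 5000 nM to 100000 nM, and a real chance that this assay again reports only a limit for compound 4.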

Compound 4, half-maximal inhibitory concentration: 32200 nM
Compound 4: the middle estimate sits 1.1-fold (0.03 log units) below what was measured, and the stated range covers the measured number.
By their numbers in this assay, from the lowest: compounds 2 and 3 (each within the scatter of the next); then compound 4. At a limit, above all of these: compound 1.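

In this assay compound 1 gives > 64000 nM as a limit of the assay and not a number. Among these compounds, on a nitrogen on an aromatic ring, the group of 8 carbon and 1 nitrogen in place of the group carrying fluorine brings a finite value into this position for the first time, and the change goes with an at least 1.9-fold lower number from compound 1 to compound 4 (0.29 log units; that floor lies within the scatter) as the first step that can be read at all. Going by these compounds, only a floor is known for this step, and its true size remains open: the limit of > 64000 nM in this assay, at which 1 of the 4 values shown sits.

This single pair cannot separate the loss of fluorine from the gain of a carbon within the exchanged group, and it sets no trend. On these data alone, how an amine or a carboxylic acid on the six-membered aromatic ring of this group would read in this assay also remains open.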